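Cycloheptyl in Place of Dichlorophenyl: an Expected Low Signal

A few compounds are considered here, and "the series" means these few. Any claim that something is new, unique, unknown or untested is made for them only; others in the source may bear on it.

Compound 1 `Nc1scc(CN2CCN(c3cccc(Cl)c3Cl)CC2)c1C(=O)c1ccc(Cl)cc1`: 2%
Compound 2 `Nc1scc(CN2CCN(c3ccc(Cl)c(C(F)(F)F)c3)CC2)c1C(=O)c1ccc(Cl)cc1`: 0%

In an assay on CHO cells for displacement of a labelled ligand from adenosine receptor A1 (Homo sapiens), read by scintillation counting, with a stated time of 120 min, tested at 10 uM (a higher number here means more inhibition at the concentration tested (going by the name of the read-out), a lower number less inhibition), compound 1 gives 2% and compound 2 gives 0%. Compound 1 holds the larger of the two numbers only nominally, since a number 2 percentage points lower from compound 1 to compound 2 (within the scatter). Compound 3 `Nc1scc(CN2CCN(C3CCCCCC3)CC2)c1C(=O)c1ccc(Cl)cc1` has not been tested; it differs from compound 1 by cycloheptyl in place of 2,3-dichlorophenyl on an amine nitrogen in a ring. Among the compounds with values here, the one measured step exchanges one aromatic ring for another and barely moves this assay; no measured step replaces an aromatic ring by a non-aromatic one, so it offers limited guidance. The expected step is a number 1 percentage points higher from compound 1 to compound 3 (within the scatter), with compound 3 estimated at 3% (range 0% to 18%).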

Compound 3, a percentage reported as inhibition, at one concentration (the size of the read-out at that concentration, not a potency): 0%
Compound 3: the middle estimate sits 3 percentage points above what was measured, within the range that was stated.
By their numbers in this assay, from the lowest: compounds 2, 3 and 1 (each within the scatter of the next).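

Putting a non-aromatic ring on this amine nitrogen in a ring adds something the two aryl compounds could not show: in this assay there is a number 2 percentage points lower from compound 1 to compound 3 (within the scatter), and no change at the digits printed from compound 2 to compound 3 (within the scatter). Cycloheptyl therefore reads the same as both substituted phenyl rings, so an aromatic ring at this place does not separate these three compounds. No supporting measurement explains this flat result.

Still open, from the compounds shown here alone, is whether a group carrying a carboxylic acid or a longer chain with a terminal amine on this nitrogen would give a clearly higher number.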